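A Methyl in Place of a Chloro on the Anilino Ring

The source may report more compounds than this note shows. Statements on the series, on what has been measured and on what is new or still open speak of the compounds shown alone.

The measured compounds so far:
Compound 1, `C#CCSc1nc(Nc2cccc(C(F)(F)F)c2)c(C#N)c(-c2ccccc2)n1`, in a functional assay on MCF7 cells (Homo sapiens) for inhibition, read by MTT assay, with a stated time of 72 h (on this read-out higher numbers stand for weaker inhibition and lower numbers for stronger inhibition), reaches only a limit, > 128000 nM.
Compound 2, `C#CCSc1nc(Nc2ccccc2Cl)c(C#N)c(-c2ccccc2)n1`, in this assay gives 24200 nM.
Compound 3, `N#Cc1c(Nc2ccc(Cl)cc2)nc(SCc2cn(Cc3ccccc3Cl)nn2)nc1-c1ccccc1`, in this assay gives 6520 nM.

Among these, compound 3 holds the lowest of the two numbers reported. Compound 2 sits at a number higher than that of compound 3 by a margin beyond the usual scatter, while compound 1 contributes no number at all, only a limit, as set out in the limit of > 128000 nM in this assay, at which 1 of the 3 values shown sits. Among the measured compounds shown here, no two of the measured compounds differ from one another in a single place, so no step between measured compounds can be read off.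

Compound 4, `Cc1ccc(Nc2nc(SCc3cn(Cc4ccccc4Cl)nn3)nc(-c3ccccc3)c2C#N)cc1`, has not yet been measured in this assay. It differs from compound 3 by methyl in place of chloro on an aromatic carbon. The exchange keeps the heavy-atom count, adds no ring, no hydrogen-bond donor and no hydrogen-bond acceptor, and brings no charge.

For the measured compounds named here, with no measured pair showing what such an exchange does here, the step from compound 3 to compound 4 is expected to be small, most likely within the scatter, with if anything a slight drift toward weaker inhibition. In this assay compound 4 is therefore expected to give about 9000 nM, within a range from 3000 nM to 27000 nM. This amounts to an expected step of a 1.4-fold higher number from compound 3 to compound 4 (0.14 log units; within the scatter).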

Compound 4, half-maximal inhibitory concentration: 9420 nM
Compound 4: the middle estimate sits 1.0-fold (0.02 log units) below what was measured; measured number inside the range.
By their numbers in this assay, from the lowest: compounds 3 and 4 (each within the scatter of the next); then compound 2. At a limit, above all of these: compound 1.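

Among the compounds shown here, exchanging chloro for methyl gives the first step that can be read in this assay, and it is a 1.4-fold higher number from compound 3 to compound 4 (0.16 log units; within the scatter). The earlier compounds shown here differed from one another in more than one place, so they could say nothing about any single group, whereas this pair isolates one place on the anilino ring, para to a large group, and there 4-chlorophenyl and 4-methylphenyl cannot be told apart in this read-out. Nothing among the data shown accounts for this outcome, and the one limit on record does not bear on this pair.

What the compounds shown leave open is whether this place accepts only chloro and methyl or also something quite different, such as an amine, a carboxylic acid or a longer chain, since this single exchange does not show how far the result extends. Compounds 1 and 2 each differ from compound 3 and compound 4 in more than one place, so the steps that would show what the group on the sulfur contributes, or where the substituent on the anilino ring sits, cannot be read.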